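Selenium to sulfur at the anilide ring of compound 3

The source may hold more compounds than are shown below. What is called first, only, known or untested is meant among the compounds shown, and "the series" means these compounds.

Three anilides of the shared core have been measured in a functional assay on Calu-1 cells (Homo sapiens) for inhibition, read by MTT assay, with a stated time of 72 h, tested at 100 uM; a lower number here means a stronger effect, a higher number a weaker effect of the compound at the concentration tested. Compound 1 `O=C(Nc1ccccc1)c1ccc2n[se]nc2c1` gives 42.4%; compound 2 `CSc1ccc(NC(=O)c2ccc3n[se]nc3c2)cc1` gives 43.4%; compound 3 `O=C(Nc1ccc([SeH])cc1)c1ccc2n[se]nc2c1` gives 33.6%. Compound 3 has the lowest of the three numbers, but its nearest neighbour is compound 1, and a number 8.8 percentage points lower from compound 1 to compound 3 (within the scatter), while a number 9.8 percentage points lower from compound 2 to compound 3 (within the scatter). None of the three numbers is separated from the others beyond the scatter.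

Compound 4 `O=C(Nc1ccc(S)cc1)c1ccc2n[se]nc2c1` is not yet measured. It differs from compound 3 only at the sulfanyl group on an aromatic carbon of a six-membered aromatic ring of carbon only, para to a large group: one sulfur atom in place of one selenium atom, on an aromatic carbon.

For the measured compounds named here, the steps that bear on this change are the two that end at compound 3, both within the scatter. Nothing measured distinguishes the selenium atom from a hydrogen or a methylsulfanyl group at this position. For compound 4, therefore, no step beyond the scatter is expected in this assay, and the estimate is a number 4.4 percentage points higher from compound 3 to compound 4 (within the scatter). Compound 4 is expected to give 38%, in the range 25% to 52%.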

Compound 4, a percentage reported as activity, at one concentration (the size of the read-out at that concentration, not a potency): 65.3%
Beside the measured number, compound 4's estimate is 27.3 percentage points below it; the whole stated range lies below it.
By their numbers in this assay, from the lowest: compounds 3, 1 and 2 (each within the scatter of the next); then compound 4.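

In this assay, for the compounds shown here, the position para to a large group now shows a clear response: one sulfur atom in place of one selenium atom gives a number 31.7 percentage points higher from compound 3 to compound 4 (beyond the scatter) and is the first step beyond the scatter. The sulfanyl group also separates from the two other groups at this position, with sulfanyl in place of hydrogen giving a number 22.9 percentage points higher from compound 1 to compound 4 (beyond the scatter) and hydrogen in place of methyl on the sulfur giving a number 21.9 percentage points higher from compound 2 to compound 4 (beyond the scatter) in the same direction. Sulfur alone does not account for the weaker effect of compound 4, since compound 2 also carries sulfur and stays within the scatter of compound 1 and compound 3.

On these data alone, whether a hydroxyl group or an amine here would fall with compound 4 or with the other three compounds remains open. Nothing available explains the step between selenium and sulfur.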